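The source may report more compounds than this note shows. Statements on the series, on what has been measured and on what is new or still open speak of the compounds shown alone.

Four compounds are compared in a functional assay on CCRF-CEM cells (Homo sapiens) for cytotoxicity, read by MTT assay, with a stated time of 72 h; a higher number here means a weaker inhibitor of growth, a lower number a stronger inhibitor of growth. Compound 1, `CCCCCSc1nc(NCc2ccc([Se]C)cc2)c2ccccc2n1`, gives > 100000 nM, which is a limit of this assay rather than a number, sitting at the limit of > 100000 nM in this assay, at which 1 of the 3 values shown sits. Compound 2, `CSc1nc(NCc2ccc([Se]C)cc2)c2ccccc2n1`, gives 63300 nM. The change from compound 1 to compound 2 is hydrogen in place of butyl on a saturated chain carbon bound to a sulfur, and it brings an at least 1.5-fold lower number from compound 1 to compound 2 (0.19 log units; that floor lies within the scatter). Compound 3, `CCCCC[Se]c1nc(N)c2cccnc2n1`, rests on another core; the difference between the two cores is not broken down here. In this assay compound 3 gives 12900 nM, the lower of the two numbers shown, and its gap to compound 2 lies beyond the scatter. Compound 4, `C[Se]c1nc(N)c2cccnc2n1`, awaits measurement. It differs from compound 3 by hydrogen in place of butyl on a saturated chain carbon bound to a selenium atom. The place is not identical to the earlier one: there the chain carbon is bound to a sulfur, here to a selenium atom, so this is the same kind of change, not the same change. Because an at least 1.5-fold lower number from compound 1 to compound 2 (0.19 log units; that floor lies within the scatter) reached only a floor within the scatter, a small step is expected, a 1.3-fold lower number from compound 3 to compound 4 (0.11 log units; within the scatter). Compound 4 is thus estimated at 10000 nM, between 4000 nM and 30000 nM.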

Compound 4, concentration for 50% growth inhibition: 68400 nM
Estimate against measurement, compound 4: 6.8-fold (0.84 log units) below, outside the stated range (above it).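

In this assay, hydrogen in place of butyl on a saturated chain carbon bound to a selenium atom gives a 5.3-fold higher number from compound 3 to compound 4 (0.72 log units; beyond the scatter). The same kind of change therefore does not carry over in any simple way from one core to the other: the same change on two cores in this assay, an at least 1.5-fold lower number (0.19 log units; that floor lies within the scatter) from compound 1 to compound 2 and a 5.3-fold higher number (0.72 log units; beyond the scatter) from compound 3 to compound 4, at least 8.3-fold (0.92 log units) apart, beyond the scatter of two such steps This does not show what lies behind the mismatch: the two pairs differ in their cores and also in the atom holding the chain, a sulfur in one and a selenium atom in the other, and each core is represented by a single pair.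

On these data alone, it remains open how an ethyl or propyl chain on the selenium atom would read on the core of compound 3, and whether a sulfur there would give a step like the one from pentyl to methyl seen with selenium. As far as these compounds go, compound 1 gives > 100000 nM, which is a limit and not a number, so the full size of the step on its core also stays open.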